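A few compounds are considered here, and "the series" means these few. Any claim that something is new, unique, unknown or untested is made for them only; others in the source may bear on it.

The measured compounds and their values in this assay:

compound 1, `C[C@H](Nc1c(C(N)=O)nnc2ccc(-c3ccc(OCCCN4CCCC4)nc3)cc12)C1CCOCC1`: 1.9
compound 2, `Cc1cn(C)nc1[C@H](C)Nc1c(C(N)=O)nnc2ccc(-c3ccc(OCCCN4CCCC4)nc3)cc12`: 2.1
compound 3, `CNC(=O)c1nnc2ccc(-c3ccc(OCCCN(C)C)nc3)cc2c1N[C@@H](C)C1CCOCC1`: 2.3

All three were run in a physicochemical assay for lipophilicity, using the shake flask method, measured as octanol-water partition, with a stated time of 30 min, at pH 7.4; on this read-out higher numbers stand for higher lipophilicity and lower numbers for lower lipophilicity. Compound 1 and compound 2 share one core and differ only by 1,4-dimethyl-1H-pyrazol-3-yl in place of oxan-4-yl on a saturated chain carbon bound to a nitrogen on an aromatic ring and a saturated chain carbon. That change gave a number 0.20 log units higher from compound 1 to compound 2 (within the scatter). Compound 3 sits on a second core; how it differs from compound 1 is not broken down here. Within this small set compound 3 has the highest number: its gap to compound 2 lies within the scatter, while its gap to compound 1 lies beyond it.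

Compound 4, `CNC(=O)c1nnc2ccc(-c3ccc(OCCCN(C)C)nc3)cc2c1N[C@@H](C)c1nn(C)cc1C`, has not yet been measured. It is the partner of compound 3 on the second core and differs from it by 1,4-dimethyl-1H-pyrazol-3-yl in place of oxan-4-yl on a saturated chain carbon bound to a nitrogen on an aromatic ring and a saturated chain carbon. This is the same change that separates compound 1 from compound 2, made at the same place, and it occurs twice among the compounds shown.

Compound 4 is expected to follow the first pair, with an estimated step of a number 0.20 log units higher from compound 3 to compound 4 (within the scatter), because the same change on the first core gave a number 0.20 log units higher from compound 1 to compound 2 (within the scatter). Since that step lay within the scatter, compound 4 is expected to land close to compound 3, at an estimated 2.5, with a range from 2.1 to 2.9.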

Compound 4, distribution coefficient: 2.3
The estimate for compound 4 lay 0.20 log units above the measured number; low and high end bracket the measured number.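

In this assay, putting 1,4-dimethyl-1H-pyrazol-3-yl in place of oxan-4-yl, on a saturated chain carbon bound to a nitrogen on an aromatic ring and a saturated chain carbon, gave no change at the digits printed from compound 3 to compound 4 (within the scatter) on the second core, and on the core of compound 1 it gave a number 0.20 log units higher from compound 1 to compound 2 (within the scatter) in the same assay. The two pairs therefore agree in one limited sense: on both cores this change stays within the scatter, but two pairs cannot show that it has a real effect on the read-out, that the two cores respond alike or differently, or that the result would hold on a third core. Nothing measured here offers a reason for either step.

The compounds shown leave open whether the read-out would also stay within the scatter with other groups at this place, such as cyclohexyl, phenyl or a piperidin-4-yl ring carrying a basic amine, in place of oxan-4-yl. Within the data shown here, they also leave open what each of the separate differences between the two cores contributes on its own, as compound 1 and compound 3 differ in more than one place and no pair here isolates any one of those differences.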